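Methylsulfanyl for methoxy on a chalcone ring

The source may report more compounds than this note shows. Statements on the series, on what has been measured and on what is new or still open speak of the compounds shown alone.

Of the compounds shown here, two have been tested so far. Compound 1 `COc1cc(OC)c(C(=O)/C=C/c2ccccc2SC)c(OC)c1` carries three methoxy groups on one ring and a methylsulfanyl group on the other; in a functional assay on HCT-116 cells (Homo sapiens), read by fluorescence and BrdU incorporation, with a stated time of 48 h, tested at 25 uM (on this read-out lower numbers stand for a stronger effect and higher numbers for a weaker effect at the one concentration tested), compound 1 gives 0.5%. Compound 2 `COc1cc(O)c(C(=O)/C=C/c2ccccc2OC)c(OC)c1` keeps a hydroxy group in place of one methoxy on the first ring and bears a methoxy group on the second; in this assay compound 2 gives 27%. On these two numbers compound 2 stands highest, and its nearest neighbour, compound 1, lies well below it, beyond the usual scatter.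

Compound 3 `COc1cc(O)c(C(=O)/C=C/c2ccccc2SC)c(OC)c1` is the next step from compound 2. The change is methylsulfanyl in place of methoxy on an aromatic carbon, set on an aromatic carbon of a six-membered aromatic ring of carbon only, ortho to a large group. Among the compounds with values here, no measured pair differs in exactly this way, so the size of the step in this assay is not known from the data. Since compound 1, which also carries the methylsulfanyl group, gives 0.5%, a step toward lower numbers from compound 2 is expected, likely beyond the scatter; the expected step is a number 21 percentage points lower from compound 2 to compound 3 (beyond the scatter). Compound 3 is therefore estimated at 6%, within a range from 0.5% to 22%.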

Compound 3, a percentage reported as activity, at one concentration (the size of the read-out at that concentration, not a potency): 28%
Beside the measured number, compound 3's estimate is 22 percentage points below it, and the stated range ends below it.
By their numbers in this assay, from the lowest: compound 1; then compounds 2 and 3 (each within the scatter of the next).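

In this assay, methylsulfanyl in place of methoxy on an aromatic carbon, ortho to a large group, gives a number 1 percentage points higher from compound 2 to compound 3 (within the scatter), so with the hydroxy group kept on the first ring, this exchange leaves the read-out where it was. The second change, hydrogen in place of methyl on an oxygen on an aromatic ring, gives a number 27.5 percentage points higher from compound 1 to compound 3 (beyond the scatter), so methylsulfanyl alone does not carry the low number of compound 1: compound 3 has the same group, and the step goes with the methyl on that oxygen. Nothing given here accounts for either step.

Whether the exchange of methoxy for methylsulfanyl would stay as small with the methyl on that oxygen remains open, as the compounds shown offer no such pair. Also open, as far as these compounds go, is how this position would respond to a different kind of group, such as an amine, a carboxylic acid or a longer chain on the sulfur, and how far the step from methyl to hydrogen on the oxygen holds in other compounds.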